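This account rests on a few compounds, and the source may have more. Where it says the series, first, only, none or still open, it means among the compounds named here.

The three measured compounds share one core and differ only in the groups on the amine nitrogen. Compound 1 `Cc1ccc2cc(CN(Cc3ccc(Cl)cc3)Cc3ccc(Cl)cc3)c(=O)[nH]c2c1` was examined in a toxicity assay on MDCK cells (Canis lupus familiaris) for cytotoxicity, read by crystal violet staining, with a stated time of 48 h; a lower number here means that less compound is tolerated, a higher number that more compound is tolerated. In this assay compound 1 returns only a limit of > 33000 nM. Compound 2 `CCc1ccc2[nH]c(=O)c(CN(Cc3ccc(F)cc3)Cc3ccc4ccccc4c3)cc2c1` also returns only a limit, with compound 2 at > 5000 nM in this assay. Compound 3 `Cc1ccc2[nH]c(=O)c(CN(Cc3ccc(OC(C)C)cc3)Cc3ccc(C(C)(C)C)cc3)cc2c1` stands at a limit as well, compound 3 giving > 5000 nM in this assay. None of the three therefore yields a number; the values sit at the limit of > 33000 nM in this assay, at which 1 of the 3 values shown sits, and at the limit of > 5000 nM in this assay, at which 2 of the 3 values shown sit. Compound 4 `Cc1ccc2[nH]c(=O)c(CN(Cc3ccc(C(C)(C)C)cc3)C(C)c3ccc(F)cc3)cc2c1` differs from compound 3 in one place: 1-(4-fluorophenyl)ethyl in place of 4-isopropoxybenzyl on an amine nitrogen. Among the measured compounds shown here, no step between two measured compounds exists here, and three limits give no direction to read from. Compound 4 is expected to show no change beyond the scatter in this assay, the expected step being a step that the limit leaves unreadable from compound 3 to compound 4. The estimate for compound 4 is 10000 nM, within a range from 4000 nM to 40000 nM, most probably reported once more only as a limit.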

Compound 4, half-maximal cytotoxic concentration: > 33000 nM
Compound 4: a limit, no number; the forecaster's own chance of this, stated with the estimate: 80%; middle value at least 3.3-fold (0.51 log units) from the limit.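

In this assay compound 4 returns only a limit, > 33000 nM. Compound 3 also stands at a limit, so no step can be read between compound 3 and compound 4. The compounds shown leave open where any actual half-maximal cytotoxic concentration lies, and whether changing the amine nitrogen's groups shifts it.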